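From compound 3 to compound 4: expected cytotoxicity step

The source may report more compounds than this note shows. Statements on the series, on what has been measured and on what is new or still open speak of the compounds shown alone.

Measured in an ADME assay on A549 cells (Homo sapiens) for cytotoxicity, read by resazurin assay, with a stated time of 48 h (on this read-out lower numbers stand for higher toxicity in this test and higher numbers for lower toxicity in this test), so far:
compound 1 `CCCNc1ccc(NC(=O)c2cc(Cl)ccc2O)c(Cl)c1` gives 22500 nM
compound 2 `O=C(Nc1ccc(NCc2ccc(Cl)cc2)cc1Cl)c1cc(Cl)ccc1O` gives 59700 nM
compound 3 `O=C(Nc1ccc(NCc2cccnc2Cl)cc1Cl)c1cc(Cl)ccc1O` gives 101000 nM

For compound 3 at 101000 nM the closest measured step is a 1.7-fold higher number from compound 2 to compound 3 (0.23 log units; within the scatter) and the widest is a 4.5-fold higher number from compound 1 to compound 3 (0.65 log units; beyond the scatter) on the same scale. Next, bis(3-hydroxypropyl)amino replaces ((2-chloropyridin-3-yl)methyl)amino on an aromatic carbon to give compound 4 `O=C(Nc1ccc(N(CCCO)CCCO)cc1Cl)c1cc(Cl)ccc1O` with bis(3-hydroxypropyl)amino in place of ((2-chloropyridin-3-yl)methyl)amino on an aromatic carbon as the counted difference.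

All measured steps alter the group on that nitrogen. Compound 1, alone in having no ring in that group, sets the modest steps of a 2.7-fold higher number from compound 1 to compound 2 (0.42 log units; beyond the scatter) and a 4.5-fold higher number from compound 1 to compound 3 (0.65 log units; beyond the scatter) as the evidence for a lower number when the ring is lost. That rests on one compound, and none measured carries bis(3-hydroxypropyl)amino. The expected move is a 1.4-fold lower number from compound 3 to compound 4 (0.16 log units; within the scatter) and it is expected to stay small. In this assay compound 4 is estimated at 70000 nM with an expected range from 25000 nM to 160000 nM as the working bounds.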

Compound 4, half-maximal cytotoxic concentration: 114000 nM
Beside the measured number, compound 4's estimate is 1.6-fold (0.21 log units) below it; the range from low to high includes it.
By their numbers in this assay, from the lowest: compound 1; then compounds 2, 3 and 4 (each within the scatter of the next).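

In this assay a ring in the group on this aromatic carbon is not required to reach the level of compound 3: bis(3-hydroxypropyl)amino, which has no ring, gives a 1.1-fold higher number from compound 3 to compound 4 (0.05 log units; within the scatter) and a 1.9-fold higher number from compound 2 to compound 4 (0.28 log units; within the scatter). Loss of the ring therefore does not by itself separate compound 1 from the others, since the ring-free change to compound 4 gives a 5.1-fold higher number from compound 1 to compound 4 (0.70 log units; beyond the scatter) and leaves propylamino as the only group here tied to a clearly lower number. No measurement shown accounts for these steps.

Compound 4 changes the chain and the number of chains on the nitrogen together, so the contribution of each remains unresolved. Also open, on these data alone, is how a single 3-hydroxypropyl chain, a longer chain ending in hydroxyl, or a carboxylic acid at the chain end would read here.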